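Replacing one carbonyl substituent on compound 2

The source may hold more compounds than are shown below. What is called first, only, known or untested is meant among the compounds shown, and "the series" means these compounds.

Of the compounds shown here, three built on the shared core have been measured in a functional assay on PC-3 cells (Homo sapiens), read by MTT assay, with a stated time of 48 h; a higher number here means a weaker inhibitor, a lower number a stronger inhibitor. Compound 1 (`CCN(CC)CCCNC(=O)c1ccc(C(CC)(CC)c2ccc(OCC(=O)C(C)(C)C)c(C)c2)n1CC`) gives 1800 nM, and compound 3 (`CCn1c(C(=O)NCCN(C)C)ccc1C(CC)(CC)c1ccc(OCC(O)C(C)(C)C)c(C)c1`) gives 1630 nM. Compound 2 (`CCOC(=O)CN(C)C(=O)c1ccc(C(CC)(CC)c2ccc(OCC(O)C(C)(C)C)c(C)c2)n1CC`) gives 25500 nM, the highest number of the three, and both other values lie beyond the scatter from it.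

Compound 4 (`CCn1c(C(=O)NCC(OC)OC)ccc1C(CC)(CC)c1ccc(OCC(O)C(C)(C)C)c(C)c1`) has not yet been measured. It differs from compound 2 in one place, on a carbonyl carbon: (2,2-dimethoxyethyl)amino in place of ((ethoxycarbonyl)methyl)(methyl)amino on a carbonyl carbon.

Within the data shown here, one measured step bears directly on this change. The same ((ethoxycarbonyl)methyl)(methyl)amino group leaves in a 16-fold lower number from compound 2 to compound 3 (1.19 log units; beyond the scatter), a large step beyond the scatter. The group that enters there, however, is (2-(dimethylamino)ethyl)amino, not (2,2-dimethoxyethyl)amino. Among the measured compounds shown here, no measured compound carries the latter group, so the data do not show how much of that step would carry over. A move in the same direction is therefore expected in this assay, but a smaller one, and with wide uncertainty. The expected step is a 2.8-fold lower number from compound 2 to compound 4 (0.45 log units; beyond the scatter). Compound 4 is estimated at 9000 nM, with an expected range of 2500 nM to 30000 nM.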

Compound 4, half-maximal inhibitory concentration: 14600 nM
Compound 4: middle estimate off by 1.6-fold (0.21 log units), on the low side; measured number inside the range.
By their numbers in this assay, from the lowest: compounds 3 and 1 (each within the scatter of the next); then compounds 4 and 2 (each within the scatter of the next).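

In this assay, the exchange of ((ethoxycarbonyl)methyl)(methyl)amino for (2,2-dimethoxyethyl)amino on the carbonyl carbon gives a 1.7-fold lower number from compound 2 to compound 4 (0.24 log units; within the scatter), so removing the ester-bearing group and gaining the amide hydrogen do not, in this pair, move the number beyond the scatter. The comparison with compound 3 isolates the far end of the chain, where dimethoxymethyl in place of (dimethylamino)methyl gives a 9.0-fold higher number from compound 3 to compound 4 (0.95 log units; beyond the scatter). Among these compounds, of the two groups that replace ((ethoxycarbonyl)methyl)(methyl)amino at this position, only the one ending in (dimethylamino)methyl is linked to a step beyond the scatter, so the large step seen earlier does not extend to every replacement that carries the amide hydrogen.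

The compounds shown leave open whether a primary amine or a carboxylic acid at the end of the same chain would fall nearer compound 3 or compound 4, and whether a longer chain would keep the low number of compound 3. No measurement at hand accounts for the difference between the two chain ends.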